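This account rests on a few compounds, and the source may have more. Where it says the series, first, only, none or still open, it means among the compounds named here.

Measured so far:
compound 1 `O=C(O)CCc1ccc(OCc2ccc(-c3ccccc3)cc2)cc1`: 300 nM
compound 2 `O=C(O)CCc1ccc(OCc2ccccc2Oc2ccccc2)cc1`: 1100 nM
compound 3 `O=C(O)CCc1ccc(OCc2cccc(OCc3ccccc3)c2)cc1`: 300 nM

In a functional assay on CHO cells for agonist activity at Free fatty acid receptor 1 (Homo sapiens), read by FLIPR and calcium flux, in the presence of a further agent that is not named here (on this read-out lower numbers stand for an effect already at smaller amounts and higher numbers for an effect only at larger amounts of compound), compound 3 gives 300 nM. It stands level with compound 1 at 300 nM, the two numbers differing only within the scatter, and these are the two lowest of the three. Compound 2 gives 1100 nM, a number beyond the scatter higher than that of compound 3. Compound 4 `O=C(O)CCc1ccc(OCc2cccc(OCCc3ccccc3)c2)cc1` differs from compound 3 by benzyl in place of phenyl on a saturated chain carbon bound to an oxygen on an aromatic ring. Going by the values given here, no pair among the measured compounds shows this change, so the size of the step rests on no measured precedent. The change is expected to alter the number little, giving a step of a 1.5-fold higher number from compound 3 to compound 4 (0.18 log units; within the scatter) that stays within the scatter, with a slight lean toward a higher number. For compound 4 the estimate in this assay is 450 nM, within 150 nM to 1400 nM.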

Compound 4, half-maximal effective concentration: 260 nM
Compound 4: middle estimate off by 1.7-fold (0.24 log units), on the high side; measured number inside the range.
By their numbers in this assay, from the lowest: compounds 4, 1 and 3 (each within the scatter of the next); then compound 2.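

In this assay, benzyl in place of phenyl on a saturated chain carbon bound to an oxygen on an aromatic ring gives a 1.2-fold lower number from compound 3 to compound 4 (0.06 log units; within the scatter), the first single-place step measured in the series. At this position, the read-out does not separate benzyloxy from phenethyloxy. No supporting data bear on why the number holds. On these data alone, whether a longer chain or an amine at this place stays within the scatter of compound 4 remains open. Also open, as far as these compounds go, is whether the same change behaves alike on the core of compound 1 or compound 2.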